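This account rests on a few compounds, and the source may have more. Where it says the series, first, only, none or still open, it means among the compounds named here.

Compound 3 `Cc1ccc2[nH]c3c(c2c1)CC[C@]1(C3=O)[C@@H](c2cccs2)[C@@H](c2ccccc2)N[C@@]12C(=O)Nc1ccccc12` was examined in a functional assay on A549 cells (Homo sapiens) for antiproliferative activity, read by MTT assay, with a stated time of 48 h (on this read-out higher numbers stand for weaker inhibition and lower numbers for stronger inhibition), where compound 3 gives 15000 nM. Compound 2 `O=C1Nc2ccccc2[C@]12N[C@H](c1ccccc1)[C@H](c1ccccc1)[C@@]21CCc2c([nH]c3ccc(Cl)cc23)C1=O` gives 15000 nM, the same figure at the digits reported, and compound 1 `Cc1ccc2[nH]c3c(c2c1)CC[C@]1(C3=O)[C@@H](c2ccccc2)[C@@H](c2ccccc2)N[C@@]12C(=O)Nc1ccccc12` gives 18000 nM; the step of a 1.2-fold lower number from compound 1 to compound 3 (0.08 log units; within the scatter) lies within the scatter, so all three compounds sit together on this read-out. Compound 4 `O=C1Nc2ccccc2[C@]12N[C@H](c1ccccc1)[C@H](c1cccs1)[C@@]21CCc2c([nH]c3ccccc23)C1=O` differs from compound 3 by hydrogen in place of methyl on an aromatic carbon. Among the measured compounds shown here, two measured steps bear on this change. The step of a 1.2-fold lower number from compound 1 to compound 2 (0.08 log units; within the scatter) exchanged one group for another, also on an aromatic carbon, and stayed within the scatter, and the step of a 1.2-fold lower number from compound 1 to compound 3 (0.08 log units; within the scatter) showed the same indifference at a saturated ring carbon. Nothing among these compounds suggests that the group on the aromatic carbon moves the number in this assay. Compound 4 is therefore expected to show no change at the digits printed from compound 3 to compound 4 (within the scatter), which amounts to no change beyond the scatter. The estimate for compound 4 in this assay is 15000 nM, with a range from 7000 nM to 32000 nM.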

Compound 4, half-maximal inhibitory concentration: 16000 nM
Compound 4: the middle estimate sits 1.1-fold (0.03 log units) below what was measured; the range from low to high includes it.
By their numbers in this assay, from the lowest: compounds 2, 3, 4 and 1 (each within the scatter of the next).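

In this assay the loss of the methyl group gives a 1.1-fold higher number from compound 3 to compound 4 (0.03 log units; within the scatter) and so stays within the scatter. The earlier step at this kind of carbon exchanged one substituent for another, whereas this one leaves only hydrogen, with no heavy atom, and the number still does not move beyond the scatter. The position therefore needs no methyl group to keep this level of activity, at least with thiophen-2-yl on the saturated ring carbon, but no supporting evidence accounts for this indifference.

The compounds shown leave open whether an amine, a carboxylic acid or a longer chain on this aromatic carbon would move the number beyond the scatter. They also leave open how hydrogen here reads with phenyl in place of thiophen-2-yl on the saturated ring carbon.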